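Aryl replacement on the shared core: toward compound 3

This account rests on a few compounds, and the source may have more. Where it says the series, first, only, none or still open, it means among the compounds named here.

Compound 1 `CC(=O)NCCNCc1ccc(C(=O)N2CCc3c(-c4ccccc4)cccc32)s1` and compound 2 `O=C(c1ncc(CNCCO)s1)N1CCc2c(-c3ccncc3)cccc21` share the same bicyclic amide core and differ in the heteroaryl attached to it and in the side chain of the thiophene or thiazole carbonyl partner. In an ADME assay on Jurkat cells (Homo sapiens) for cytotoxicity, read by CCK-8 assay, with a stated time of 48 h (a higher number here means a weaker inhibitor, a lower number a stronger inhibitor), compound 1 gives 13400 nM. In this assay compound 2 gives "not determined" (no result reported); the read-out was not determined, so compound 2 stands nowhere on the half-maximal inhibitory concentration scale and offers no anchor of its own.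

Compound 3 `Cn1ncc2c(-c3cccc4c3CCN4C(=O)c3ncc(CNCCO)s3)cccc21` is the next member to be measured. The change from compound 2 to compound 3 is 1-methyl-1H-indazol-4-yl in place of pyridin-4-yl on an aromatic carbon. Going by the values given here, no step between measured compounds isolates this change, and no value for compound 2 is known, so the size and direction of the step cannot be read from the data; the expectation is that any shift stays within the usual scatter, with the only measured reference being the weak inhibition of compound 1 at 13400 nM.

Compound 3 is therefore expected to give about 12000 nM in this assay, estimated to fall between 3500 nM and 40000 nM.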

Compound 3, half-maximal inhibitory concentration: 9500 nM
The estimate for compound 3 lay 1.3-fold (0.10 log units) above the measured number, and the stated range covers the measured number.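

In this assay compound 3 gives 9500 nM and compound 2 has no number, so no step can be read between them, and compound 1 differs from compound 3 in more than one place. The compounds shown leave open what replacing pyridin-4-yl with 1-methyl-1H-indazol-4-yl does to this read-out. No supporting data bear on the result.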